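The source may hold more compounds than are shown below. What is called first, only, known or untested is meant among the compounds shown, and "the series" means these compounds.

In a functional assay on MCF7 cells (Homo sapiens) for cytotoxicity, read by MTT assay, with a stated time of 72 h (a lower number here means a stronger inhibitor, a higher number a weaker inhibitor), three compounds have been measured so far:

compound 1, `CC1(C)O[C@@H](CO)[C@H](Cn2cc(Cn3c4c(c5ccccc53)C(=O)c3c[n+]([O-])c5ccccc5c3C4=O)nn2)O1`, gives 690 nM
compound 2, `O=C1c2c[n+]([O-])c3ccccc3c2C(=O)c2c1c1ccccc1n2CCCCN1CCCCC1`, gives 150 nM
compound 3, `CC1(C)OC[C@@H](Cn2cc(Cn3c4c(c5ccccc53)C(=O)c3c[n+]([O-])c5ccccc5c3C4=O)nn2)O1`, gives > 1000 nM

The value of compound 3 is a limit of the assay and not a number. Compound 2 holds the lower of the two numbers, and its gap to compound 1 lies beyond the scatter. Going by the values given here, the one measured step, an at least 1.4-fold higher number from compound 1 to compound 3 (0.16 log units; that floor lies within the scatter), runs into the limit of > 1000 nM in this assay, at which 1 of the 3 values shown sits, and concerns the substituent on the triazole arm, not the chain on the aromatic nitrogen.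

Compound 4, `CN(C)CCCCCn1c2c(c3ccccc31)C(=O)c1c[n+]([O-])c3ccccc3c1C2=O`, is not yet measured. It differs from compound 2 by (dimethylamino)methyl in place of piperidin-1-yl on a saturated chain carbon, four bonds along the chain from an aromatic nitrogen. Among the compounds with values here, no measured step bears on this change, so there is no ground for expecting a step in this assay beyond the scatter in either direction. The step from compound 2 to compound 4 is therefore expected to be about a 1.3-fold higher number from compound 2 to compound 4 (0.12 log units; within the scatter). Compound 4 is estimated at 200 nM, within a range from 80 nM to 500 nM.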

Compound 4, half-maximal inhibitory concentration: 200 nM
Estimate against measurement, compound 4: no gap at the digits printed; the measured number falls inside the stated range.
By their numbers in this assay, from the lowest: compounds 2 and 4 (each within the scatter of the next); then compound 1. At a limit, above all of these: compound 3.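

In this assay, replacing piperidin-1-yl with (dimethylamino)methyl on a saturated chain carbon, four bonds along the chain from an aromatic nitrogen, gives a 1.3-fold higher number from compound 2 to compound 4 (0.12 log units; within the scatter), so the ring of compound 2 is not required for a number at this level among the compounds shown. Going by these compounds alone, this is the only measured step on the chain on the aromatic nitrogen, as the earlier step concerned the substituent on the triazole arm. Nothing measured here gives a reason why the two groups read alike.

From the compounds shown here alone, the chains of compound 2 and compound 4 both end in an amine, so it stays open whether a morpholine, a hydroxyl or a carboxylic acid at the chain end would hold this level. Going by these compounds, it also stays open how a shorter or longer chain would read.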